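A few compounds are considered here, and "the series" means these few. Any claim that something is new, unique, unknown or untested is made for them only; others in the source may bear on it.

Two compounds of the series have numbers in a functional assay on A2780 cells (Homo sapiens) for cytotoxicity, read by sulforhodamine B assay, with a stated time of 72 h; a lower number here means a stronger inhibitor, a higher number a weaker inhibitor. Compound 1 `O=C(NCc1ccc(S(=O)(=O)c2ccccc2)cc1)NCc1cccnc1` gives 610 nM in this assay. Compound 2 `O=C(NCc1ccc(S(=O)(=O)C2CCC(F)(F)CC2)cc1)N1Cc2ccncc2C1` gives 13 nM in this assay, the lower of the two numbers, and the gap to compound 1 is beyond the scatter. Compound 3 `CN1CCN(S(=O)(=O)c2ccc(CNC(=O)N3Cc4ccncc4C3)cc2)CC1` is not yet measured; it differs from compound 2 by 4-methylpiperazin-1-yl in place of 4,4-difluorocyclohexyl on a sulfonyl sulfur. Within the data shown here, no comparable step has been measured. The change is expected to move this assay toward a somewhat higher number, by a 3.1-fold higher number from compound 2 to compound 3 (0.49 log units; beyond the scatter), though a result within the scatter of compound 2 is not excluded. Compound 3 is estimated at 40 nM, with a range from 8 nM to 200 nM.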

Compound 3, half-maximal inhibitory concentration: 71 nM
For compound 3 the middle estimate is 1.8-fold (0.25 log units) below the measured one, within the range that was stated.
By their numbers in this assay, from the lowest: compound 2; then compound 3; then compound 1.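

Among these compounds, on a sulfonyl sulfur, 4-methylpiperazin-1-yl in place of 4,4-difluorocyclohexyl gives a 5.5-fold higher number from compound 2 to compound 3 (0.74 log units; beyond the scatter) in this assay, the first measured step at this position. The step is modest, and compound 3 still reads 71 nM, so this position accepts a six-membered ring with hetero atoms as well as one of carbon only. Nothing measured here accounts for the size of the step. Two changes travel together in this step, the ring nitrogens and the loss of fluorine, and the compounds shown do not separate them. A morpholine or a 4,4-difluoropiperidine on the same sulfur would bear on that question.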